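Diethylamino gives way to (tert-butyl)amino on the shared core

The source may report more compounds than this note shows. Statements on the series, on what has been measured and on what is new or still open speak of the compounds shown alone.

Compound 1 `CCCNc1nc(Cl)nc(N[C@@H](C)c2ccccc2)n1`: 32400 nM
Compound 2 `CCN(CC)c1nc(Cl)nc(N[C@H](C)c2ccccc2)n1`: 6310 nM
Compound 3 `CC(C)Nc1nc(Cl)nc(N[C@@H](C)c2ccccc2)n1`: 23400 nM

In an ADME assay on the whole organism for inhibition, with Oryza sativa as the target, with a stated time of 4 days (on this read-out lower numbers stand for stronger inhibition and higher numbers for weaker inhibition), compound 2 gives the lowest of the three numbers, 6310 nM, clearly apart from both others. Compound 4 `C[C@@H](Nc1nc(Cl)nc(NC(C)(C)C)n1)c1ccccc1` departs from compound 2 in one place: (tert-butyl)amino in place of diethylamino on an aromatic carbon. For the measured compounds named here, the only measured single change, isopropyl in place of propyl on a nitrogen, is a 1.4-fold lower number from compound 1 to compound 3 (0.14 log units; within the scatter), so branching alone is not expected to matter much. Compound 4 instead resembles compound 1, at 32400 nM, and compound 3, at 23400 nM, in carrying an alkylamino group rather than diethylamino. A moderate rise in this assay is therefore expected, with an estimated step of a 2.2-fold higher number from compound 2 to compound 4 (0.35 log units; beyond the scatter). The estimate for compound 4 is 14000 nM, with an expected range of 5000 nM to 40000 nM.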

Compound 4, half-maximal inhibitory concentration: 9330 nM
Compound 4: middle estimate off by 1.5-fold (0.18 log units), on the high side, within the range that was stated.
By their numbers in this assay, from the lowest: compounds 2 and 4 (each within the scatter of the next); then compounds 3 and 1 (each within the scatter of the next).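

In this assay, the exchange of diethylamino for (tert-butyl)amino on this aromatic carbon gives a 1.5-fold higher number from compound 2 to compound 4 (0.17 log units; within the scatter). Compound 2 and compound 4 therefore cannot be told apart in this read-out, although (tert-butyl)amino carries a hydrogen-bond donor that diethylamino lacks. No measurement available here accounts for this result. Going by these compounds, it remains open whether a smaller group such as methylamino, or a cyclic amine such as morpholine, would read alike at this position. Replacing the chloro group with a methoxy group is equally unresolved.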